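The source may hold more compounds than are shown below. What is called first, only, known or untested is meant among the compounds shown, and "the series" means these compounds.

The compounds here share one core and are compared in a functional assay on the whole organism for inhibition, with Mythimna separata as the target, with a stated time of 5 days; a higher number here means that more compound is needed for the effect, a lower number that less compound is needed. Compound 3 `CC(C)(C)n1ncc(OCc2nnc(-c3ccc(F)cc3)o2)c(Cl)c1=O` gives 5200 nM in this assay, the higher of the two numbers reported so far. Compound 2 `CC(C)(C)n1ncc(OCc2nnc(-c3ccc(Cl)cc3)o2)c(Cl)c1=O` gives 1900 nM in this assay, and the difference between them is a 2.7-fold higher number from compound 2 to compound 3 (0.44 log units; beyond the scatter). Compound 1 `CCn1ncc(OCc2nnc(-c3ccc(F)cc3)o2)c(Cl)c1=O` yields only a limit of this assay, > 299000 nM. Measured against that limit, the change is an at least 57-fold lower number from compound 1 to compound 3 (1.75 log units; beyond the scatter).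

Compound 4 `CC(C)(C)n1ncc(OCc2nnc(-c3ccc([N+](=O)[O-])cc3)o2)c(Cl)c1=O` has not yet been measured. It differs from compound 3 by nitro in place of fluoro on an aromatic carbon. For the measured compounds named here, of the measured steps, only the one from compound 2 to compound 3 exchanges a group on an aromatic carbon of that ring, and it moved the number modestly; the step from compound 1 to compound 3 concerns the group on the aromatic nitrogen and says nothing about this exchange. Nitro has not been tried on any measured compound, so the direction is open; a modest step, of roughly the size seen between chloro and fluoro, in either direction is the most reasonable expectation. Compound 4 is therefore estimated to give 4000 nM in this assay, with a range from 900 nM to 18000 nM. The expected step is a 1.3-fold lower number from compound 3 to compound 4 (0.11 log units; within the scatter).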

Compound 4, half-maximal effective concentration: > 299000 nM
Compound 4: a limit, no number (the forecaster's own chance of this, stated with the estimate: 10%); at least 74-fold (1.87 log units) between middle value and limit.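

For the compounds shown here, the group at this place on the phenyl ring matters far more than the earlier compounds suggested: exchanging chloro for fluoro gave only a 2.7-fold higher number from compound 2 to compound 3 (0.44 log units; beyond the scatter), whereas the 4-fluorophenyl to 4-nitrophenyl change gives an at least 57-fold higher number from compound 3 to compound 4 (1.75 log units; beyond the scatter), and replacing chloro with nitro gives an at least 150-fold higher number from compound 2 to compound 4 (2.19 log units; beyond the scatter). The tert-butyl group on the aromatic nitrogen, which accompanied a large drop in the number from ethyl in an at least 57-fold lower number from compound 1 to compound 3 (1.75 log units; beyond the scatter), is therefore not enough on its own to keep a measurable effect in this assay once nitro is present. From the compounds shown here alone, the result for compound 4 is a limit, not a number, so the true size of these steps remains unknown, and it is the same limit met elsewhere in this small set: the limit of > 299000 nM in this assay, at which 2 of the 4 values shown sit.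

Three groups at this place cannot show which feature of nitro matters, and neither the hydrogen-bond acceptors counted for nitro nor its larger atom count can be singled out from this one exchange. Going by these compounds, a methoxy group, an amine or a nitrile at the same place could help separate these possibilities, and it also remains open whether an unsubstituted phenyl ring would fall nearer to chloro and fluoro or to nitro.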